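The compounds below may be only part of what the source reports. "The series", "measured", "known", "first", "only" and "open" are said of these compounds alone.

Compound 1 `CNC(=O)[C@H](c1ccc(Cl)cc1)C(C)C` is the simplest member of this small set of amides, all built on one shared core, and in a functional assay on CHO cells for agonist activity at Free fatty acid receptor 2 (Homo sapiens), read by cAMP accumulation (on this read-out lower numbers stand for stronger inhibition and higher numbers for weaker inhibition), compound 1 gives 11000 nM. Compound 2 `CC(C)[C@H](C(=O)NC(C)(C)C)c1ccc(Cl)cc1` carries a tert-butyl group on the amide-type nitrogen instead of the methyl. In this assay, among the compounds with values here, compound 2 returns only a limit of the measurement, > 100000 nM, rather than a number; it is the one value sitting at the limit of > 100000 nM in this assay, at which 1 of the 3 values shown sits. Compound 3 `CC(C)[C@H](C(=O)Nc1ccon1)c1ccc(Cl)cc1` carries a 1,2-oxazol-3-yl group at the same place, and in this assay compound 3 gives 36000 nM.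

The measured steps show an at least 9.0-fold higher number from compound 1 to compound 2 (0.95 log units; beyond the scatter) and a 3.3-fold higher number from compound 1 to compound 3 (0.51 log units; beyond the scatter), so both larger groups make the number rise, while an at least 2.7-fold lower number from compound 2 to compound 3 (0.44 log units; beyond the scatter) shows that the five-membered ring fares better than the tert-butyl.

Compound 4 `CC(C)[C@H](C(=O)Nc1cnns1)c1ccc(Cl)cc1` has not been measured. It differs from compound 2 by 1,2,3-thiadiazol-5-yl in place of tert-butyl on an amide-type nitrogen. This change mirrors the step from compound 2 to compound 3, where a small aromatic ring also replaced the tert-butyl, so a step of similar size in the same direction is expected: an at least 2.8-fold lower number from compound 2 to compound 4 (0.45 log units; beyond the scatter). Compound 4 is therefore expected to give about 35000 nM, with a likely range from 10000 nM to 120000 nM.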

Compound 4, half-maximal inhibitory concentration: 57000 nM
For compound 4 the middle estimate is 1.6-fold (0.21 log units) below the measured one; the measured number falls inside the stated range.
By their numbers in this assay, from the lowest: compound 1; then compounds 3 and 4 (each within the scatter of the next). At a limit, above all of these: compound 2.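

In this assay, a second five-membered aromatic ring behaves like the first: a 1.6-fold higher number from compound 3 to compound 4 (0.20 log units; within the scatter), so exchanging 1,2-oxazol-3-yl for 1,2,3-thiadiazol-5-yl on the amide-type nitrogen makes no change that can be told from scatter, while a 5.2-fold higher number from compound 1 to compound 4 (0.71 log units; beyond the scatter) shows that the rise over methyl is not peculiar to one ring. The comparison with tert-butyl is less firm, as an at least 1.7-fold lower number from compound 2 to compound 4 (0.24 log units; that floor lies within the scatter), so this pair alone does not establish that the new ring does better than tert-butyl. Compound 2 has only a limit of the assay, not a number: the limit of > 100000 nM in this assay, at which 1 of the 4 values shown sits.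

The compounds shown leave open whether the rise over methyl follows from the aromatic ring itself or simply from a group larger than methyl, a question that a non-aromatic group such as cyclopentyl on the same nitrogen could help to answer. They also leave open whether any group on this nitrogen, such as ethyl or cyclopropyl, could bring the number below that of compound 1.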